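Swapping the Pyridyl Ether: Permeability Outlook for Compound 4

A few compounds are considered here, and "the series" means these few. Any claim that something is new, unique, unknown or untested is made for them only; others in the source may bear on it.

Of the compounds shown here, three sharing one core have been measured in an ADME assay for permeability, using PAMPA, with a stated time of 4 h; on this read-out higher numbers stand for higher permeability and lower numbers for lower permeability. Compound 1 `Cn1c(COc2cccc(C(=O)O)c2)nc2ccc(Oc3ccc(Cl)c(F)c3)nc21` gives 25.6 10^-6 cm/s. Compound 2 `Cn1c(COc2cccc(C(=O)O)c2)nc2cnc(Oc3ccc4c(c3)OCC4)cc21` gives 3.6 10^-6 cm/s. Compound 3 `Cn1c(COc2cccc(C(=O)O)c2)nc2ccc(Oc3cc(Cl)ccn3)cc21` gives 10.3 10^-6 cm/s, the second highest of the three numbers: compound 1 stands nearest to it, with a number beyond the scatter above it, and compound 2 stands furthest away, with a number beyond the scatter below it.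

Compound 4 `Cn1c(COc2cccc(C(=O)O)c2)nc2ccc(Oc3ncc(Cl)cc3Cl)cc21` has not yet been measured in this assay. It differs from compound 3 in one place: 3,5-dichloropyridin-2-yl in place of 4-chloropyridin-2-yl on an oxygen on an aromatic ring. Both the leaving and the entering group are a six-membered aromatic ring with one hetero atom, neither carries a charge, and the hydrogen-bond donor and acceptor counts stay the same.

For the measured compounds named here, no pair of measured compounds differs in only one place, so there is no step of exactly this kind to lean on. Among the three, compound 1, whose aromatic ether bears chlorine and fluorine, gives the highest number, while compound 2, whose aromatic ether bears no halogen, gives the lowest. On that basis a modest rise in this assay is expected, a step of a 1.6-fold higher number from compound 3 to compound 4 (0.19 log units; within the scatter), though a result within the scatter would not be surprising. Compound 4 is estimated at 16 10^-6 cm/s, with a range from 7 10^-6 cm/s to 38 10^-6 cm/s.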

Compound 4, apparent permeability: 16.1 10^-6 cm/s
Beside the measured number, compound 4's estimate is 1.0-fold (0.00 log units) below it; the range from low to high includes it.
By their numbers in this assay, from the lowest: compound 2; then compounds 3, 4 and 1 (each within the scatter of the next, the first and the last beyond it).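

In this assay, putting 3,5-dichloropyridin-2-yl in place of 4-chloropyridin-2-yl on an oxygen on an aromatic ring gives a 1.6-fold higher number from compound 3 to compound 4 (0.19 log units; within the scatter), so this exchange cannot be told apart from the ordinary variation between repeat measurements. For the compounds shown here, this is the first comparison between two compounds that differ in one place only, and it shows that this particular swap of one chlorinated pyridine ring for another leaves the read-out within that variation, which the earlier compounds, differing in more than one place, could not show. No measured information here explains this outcome, so the result stands as an observation without a known cause.

Going by these compounds alone, this single step cannot separate the effect of the different chlorine pattern from any other feature of the exchange, and it covers only two closely related chlorinated rings. Going by these compounds, whether the read-out would stay this close with an amine or a carboxylic acid on the pyridine ring, or with a cyclohexyl group on the same oxygen in place of the aromatic ring, remains open.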